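This account rests on a few compounds, and the source may have more. Where it says the series, first, only, none or still open, it means among the compounds named here.

In an in vitro ADME assay on microsomes from liver (Rattus norvegicus) for metabolic stability, tested at 2 uM (a higher number here means that the compound lasts longer, a lower number that the compound disappears faster), compound 3 (`CC(C)(C#Cc1ccc(NC(=O)CSc2nnnn2-c2ccc(C3CC3)cc2Cl)c(Cl)c1)CNCC(=O)O`) gives 1.32 h and compound 2 (`CC(C)(C#Cc1ccc(NC(=O)CSc2nnnn2-c2ccc(C3CC3)cc2Cl)c(Cl)c1)NCC(=O)O`) gives 1.17 h so the two stand level, with a 1.1-fold higher number from compound 2 to compound 3 (0.05 log units; within the scatter) inside the scatter. Compound 1 (`CC(C)(C#Cc1ccc(NC(=O)CSc2nnnn2-c2ccc(C3CC3)cc2Cl)c(Cl)c1)OCC(=O)O`) at 0.483 h lies lower than both.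

The change now in view leads to compound 4 (`O=C(CSc1nnnn1-c1ccc(C2CC2)cc1Cl)Nc1ccc(C#CC2(C(=O)O)CC2)cc1Cl`) and puts 1-carboxycyclopropyl in place of 1-(((carboxymethyl)amino)methyl)-1-methylethyl on a triple-bonded carbon so the entering group holds no nitrogen. For the measured compounds named here, no measured step covers this exchange directly.

The nearest evidence is the pair a 2.4-fold higher number from compound 1 to compound 2 (0.38 log units; beyond the scatter) and a 2.7-fold higher number from compound 1 to compound 3 (0.44 log units; beyond the scatter) which are both modest and run upward on replacing carboxymethoxy with a nitrogen-bearing chain. Going by the values given here, compound 1 is the only measured compound without nitrogen in this chain, and it holds the low number. Read in reverse, these steps point to a modest fall, but the three-membered ring is untested in this set and the direction stays tentative.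

The estimate is a 1.8-fold lower number from compound 3 to compound 4 (0.25 log units; within the scatter) with a lower number expected, of a size not clearly beyond the scatter. Compound 4 is estimated at 0.75 h with 0.33 h to 1.7 h as the expected range.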

Compound 4, half-life: 0.5 h
The estimate for compound 4 lay 1.5-fold (0.18 log units) above the measured number; measured number inside the range.
By their numbers in this assay, from the lowest: compounds 1 and 4 (each within the scatter of the next); then compounds 2 and 3 (each within the scatter of the next).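

Working from the short group on the triple-bonded carbon, 1-carboxycyclopropyl holds no nitrogen and sits clearly under both nitrogen-bearing chains in this assay, with a 2.6-fold lower number from compound 3 to compound 4 (0.42 log units; beyond the scatter) and a 2.3-fold lower number from compound 2 to compound 4 (0.37 log units; beyond the scatter), so the low number is no longer confined to the carboxymethoxy-bearing compound 1. For the compounds shown here, with a 1.0-fold higher number from compound 1 to compound 4 (0.02 log units; within the scatter), the two nitrogen-free compounds stand level despite their different groups, and across these four compounds both nitrogen-bearing groups lie above both nitrogen-free ones, with no compound going against that split. Nothing measured here explains the split or ties it to the nitrogen itself, since the exchange also alters the ring content and the size of the group.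

Still open, from the compounds shown here alone, is whether the nitrogen, the three-membered ring or the overall chain governs the number: a 1-((carboxymethyl)amino)cyclopropyl group would keep the ring and the nitrogen together, while a 1-carboxy-1-methylethyl group would drop the ring with no nitrogen present. A simple amine lacking the carboxylic acid at the same place would also show whether the acid is needed for the higher numbers of compound 2 and compound 3.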